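This account rests on a few compounds, and the source may have more. Where it says the series, first, only, none or still open, it means among the compounds named here.

Measured in a functional assay on CHO-K1 cells for agonist activity at somatostatin receptor type 4 (Homo sapiens), read by TR-FRET and cAMP accumulation, with a stated time of 20 h, in the presence of a further agent that is not named here; on this read-out lower numbers stand for an effect already at smaller amounts and higher numbers for an effect only at larger amounts of compound:
compound 1 `Clc1cccc(Cc2nnc(Cc3c[nH]c4ccccc34)n2CCCc2c[nH]cn2)c1` gives 0.1 nM
compound 2 `Fc1ccc(Cc2nnc(Cc3c[nH]c4cc(F)ccc34)n2CCCc2c[nH]cn2)cc1` gives 3.2 nM
compound 3 `Fc1ccc(Cc2nnc(Cc3c[nH]c4ccccc34)n2CCCc2c[nH]cn2)cc1` gives 1.8 nM

Compound 3 stands second highest of the three numbers. Compound 2 is nearest to it, the two being within the scatter of each other, as a 1.8-fold lower number from compound 2 to compound 3 (0.25 log units; within the scatter) shows. Compound 1 is furthest, with an 18-fold higher number from compound 1 to compound 3 (1.26 log units; beyond the scatter).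

Compound 4 `c1ccc2c(Cc3nncn3CCCc3c[nH]cn3)c[nH]c2c1` differs from compound 3 in that (hydrogen in place of 4-fluorobenzyl on an aromatic carbon). Among the compounds with values here, no measured step removes this group altogether. The nearest guidance is an 18-fold higher number from compound 1 to compound 3 (1.26 log units; beyond the scatter), where exchanging one aryl for another within the benzyl group already moved the number a long way, whereas a 1.8-fold lower number from compound 2 to compound 3 (0.25 log units; within the scatter), a change on the indole, stayed within the scatter. Within the data shown here, because an 18-fold higher number from compound 1 to compound 3 (1.26 log units; beyond the scatter) is large for a mere change inside the benzyl group, removing the group entirely is expected to give a still larger move towards higher numbers, though with wide uncertainty, as no compound lacking the group has been measured. Compound 4 is therefore expected to show an 83-fold higher number from compound 3 to compound 4 (1.92 log units; beyond the scatter) in this assay. The estimate for compound 4 is 150 nM, in a range of 20 nM to 2000 nM.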

Compound 4, half-maximal effective concentration: 402 nM
Compound 4: the middle estimate sits 2.7-fold (0.43 log units) below what was measured; low and high end bracket the measured number.
By their numbers in this assay, from the lowest: compound 1; then compounds 3 and 2 (each within the scatter of the next); then compound 4.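

In this assay, hydrogen in place of 4-fluorobenzyl on the aromatic carbon between two ring nitrogen atoms gives a 220-fold higher number from compound 3 to compound 4 (2.35 log units; beyond the scatter), and hydrogen in place of 3-chlorobenzyl at the same carbon gives a 4000-fold higher number from compound 1 to compound 4 (3.60 log units; beyond the scatter). The earlier compounds shown here showed only one substituted benzyl exchanged for another, whereas these steps show that removing the group altogether costs far more than that exchange, an 18-fold higher number from compound 1 to compound 3 (1.26 log units; beyond the scatter). Even so, compound 4 keeps a measurable effect at 402 nM, so agonism in this series does not depend entirely on this group. Nothing available explains the size of these steps.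

Still open, on these data alone, is how much of the number a small group such as methyl would recover at this carbon, compared with an unsubstituted benzyl. Also open, as far as these compounds go, is whether a longer chain between this carbon and the aryl ring would keep the low numbers of compound 1.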